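Pentyl in Place of Isopropyl on the Shared Core

A few compounds are considered here, and "the series" means these few. Any claim that something is new, unique, unknown or untested is made for them only; others in the source may bear on it.

Compound 1 `COc1ccc(Nc2cc(C(C)C)oc(=O)c2)cc1` was examined in a functional assay on KB cells (Homo sapiens) for cytotoxicity, read by MTT assay, with a stated time of 72 h; a higher number here means that more compound is needed for the effect, a lower number that less compound is needed. In this assay compound 1 gives > 30 uM, which is a limit of the assay rather than a number. Compound 2 `O=c1cc(NC2CC2)cc(-c2ccccc2)o1` was run in the same setting. In this assay compound 2 gives > 30 uM, again a limit. For the measured compounds named here, both measured values sit at the same limit (the limit of > 30 uM in this assay, at which 2 of the 2 values shown sit), so compound 1 stands level with the only other compound measured, and no step between two measured compounds can be read. Compound 3 `CCCCCc1cc(Nc2ccc(OC)cc2)cc(=O)o1` differs from compound 1 in one place: pentyl in place of isopropyl on an aromatic carbon. With nothing measured beyond the limit, the data give no direction for this change. The step is expected to be none beyond the scatter, a number no higher from compound 1 to compound 3 (the limit leaves the size open). Compound 3 is therefore estimated to give 30 uM, within 10 uM to 100 uM, with a limit again the most probable outcome.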

Compound 3, concentration for half-maximal effect: 10.1 uM
The estimate for compound 3 lay 3.0-fold (0.47 log units) above the measured number; the range from low to high includes it.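

In this assay, pentyl in place of isopropyl on this aromatic carbon next to the ring oxygen gives an at least 2.9-fold lower number from compound 1 to compound 3 (0.47 log units; beyond the scatter). This position therefore responds to a change of the alkyl chain alone, with no ring, hydrogen-bond donor or hydrogen-bond acceptor entering, and compound 3 is the only one of the compounds shown with a value that is not a limit. The step gives only a minimum, and its full size stays open: the limit of > 30 uM in this assay, at which 2 of the 3 values shown sit.

The compounds shown do not separate the effect of chain length from that of losing the branch, which a propyl or a longer chain such as heptyl would help to settle. They also leave open whether an amine or a carboxylic acid at the end of the pentyl chain would keep the lower number.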